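Triazole substituent swap on a shared chromene core

The compounds below may be only part of what the source reports. "The series", "measured", "known", "first", "only" and "open" are said of these compounds alone.

The three measured compounds share one core and differ only in the group on an aromatic nitrogen of the triazole ring. Compound 1 `CCOC(=O)C1=Cc2ccccc2OC1(OCc1cn(CC(=O)Nc2cccc(F)c2)nn1)C(F)(F)F` carries a ((3-fluorophenyl)carbamoyl)methyl group there; in a functional assay on HeLa cells (Homo sapiens) for inhibition, read by MTT assay, with a stated time of 24 h (on this read-out lower numbers stand for stronger inhibition and higher numbers for weaker inhibition), compound 1 gives > 150000 nM, which is a limit of the assay rather than a number. Compound 2 `CCOC(=O)C1=Cc2ccccc2OC1(OCc1cn(-c2ccccc2)nn1)C(F)(F)F` carries a phenyl group, and in this assay compound 2 also gives only a limit, > 150000 nM. Compound 3 `CCCCCCCCn1cc(COC2(C(F)(F)F)Oc3ccccc3C=C2C(=O)OCC)nn1` carries an octyl group, and in this assay compound 3 stands at a limit too, > 150000 nM. Because of the limit of > 150000 nM in this assay, at which 3 of the 3 values shown sit, none of the steps can be read: a step that the two limits leave unreadable from compound 1 to compound 2, a step that the two limits leave unreadable from compound 1 to compound 3 and a step that the two limits leave unreadable from compound 2 to compound 3 all stay hidden.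

Compound 4 `CCOC(=O)C1=Cc2ccccc2OC1(OCc1cn(-c2ccc([N+](=O)[O-])cc2)nn1)C(F)(F)F` differs from compound 3 by 4-nitrophenyl in place of octyl on an aromatic nitrogen. Since every measured compound sits at the same limit, no readable step bears on this change, and no shift beyond the scatter can be predicted in either direction. Compound 4 is therefore expected to give 150000 nM, within 30000 nM to 500000 nM. The expected step is a number no higher from compound 3 to compound 4 (the limit leaves the size open), and most likely compound 4 will again be reported only as a limit.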

Compound 4, half-maximal inhibitory concentration: > 150000 nM
Compound 4 gave a limit, no number; the forecaster's own chance of this, stated with the estimate: 75%; the middle value sits exactly at the limit.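

No new step can be read between compound 4 and compound 1, compound 2 or compound 3, because each value is a limit and not a number: the limit of > 150000 nM in this assay, at which 4 of the 4 values shown sit. The compounds shown leave open how these four groups on the aromatic nitrogen rank against one another in this assay.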